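The source may hold more compounds than are shown below. What is called first, only, known or untested is meant among the compounds shown, and "the series" means these compounds.

Compound 1 `COc1cc(-n2c(-c3ccccc3)cn(C(C)=O)c2=O)cc(OC)c1OC`: > 50000 nM (a limit)
Compound 2 `COc1cc(-n2c(-c3ccc(Br)cc3)cn(C(C)=O)c2=O)cc(OC)c1OC`: 1000 nM

Going by the values given here, in a functional assay on K562 cells (Homo sapiens) for cytotoxicity, read by MTT assay, with a stated time of 48 h (a higher number here means a weaker inhibitor, a lower number a stronger inhibitor), compound 2 gives 1000 nM, the only true number so far. Compound 1 reads > 50000 nM, which is a limit. Compound 3 `COc1cc(-n2c(-c3ccc(Cl)cc3)cn(C(C)=O)c2=O)cc(OC)c1OC` has chloro in place of bromo on an aromatic carbon. Among the compounds with values here, the one measured step that bears on this is an at least 50-fold lower number from compound 1 to compound 2 (1.69 log units; beyond the scatter), with bromo in place of hydrogen. Compound 3 still carries a group other than hydrogen there, so most of that large gain is expected to remain. A small step towards a higher number is expected, a 1.8-fold higher number from compound 2 to compound 3 (0.26 log units; within the scatter). For compound 3 the estimate is 1800 nM, with an expected range of 500 nM to 6000 nM.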

Compound 3, half-maximal inhibitory concentration: > 50000 nM
Compound 3: no number, only a limit; the forecaster's own chance of this, stated with the estimate: 10%; at least 27-fold (1.44 log units) between middle value and limit.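

In this assay, the gain at this position does not come from just any group other than hydrogen: chloro in place of bromo gives an at least 50-fold higher number from compound 2 to compound 3 (1.69 log units; beyond the scatter). Among these compounds, the 4-bromophenyl and 4-chlorophenyl groups are therefore not interchangeable, and only bromo gives a readable value. The step between hydrogen and chloro cannot be read, because both compounds sit at a limit: the limit of > 50000 nM in this assay, at which 2 of the 3 values shown sit.

Going by these compounds, it remains open whether bromo alone works on this aromatic carbon. Iodo, methyl or an amine at the same place could separate these possibilities.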